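A Pyrazole in Place of a Nitrile Chain

This account rests on a few compounds, and the source may have more. Where it says the series, first, only, none or still open, it means among the compounds named here.

Of the compounds shown here, two sharing one core have been tested for how well they dissolve. In a physicochemical assay for solubility, in phosphate buffer, with a stated time of 18 h (a lower number here means a less soluble compound, a higher number a more soluble compound), compound 1 `N#Cc1c(N)nc2nc(Cc3ccccc3)ncc2c1N` gives 13000 nM. Compound 2 `CC(C)(C)c1nc(CCCCCC#N)c2c(N)c(C#N)c(N)nc2n1` gives 6000 nM in this assay, the lower of the two numbers; the gap to compound 1 lies beyond the usual scatter, so compound 2 is the less soluble of the pair. Compound 3 `CC(C)(C)c1nc(-c2ccn[nH]2)c2c(N)c(C#N)c(N)nc2n1` has not yet been measured. It differs from compound 2 in one place: 1H-pyrazol-5-yl in place of 5-cyanopentyl on an aromatic carbon. Within the data shown here, no measured pair here shows what such an exchange does to solubility, so the expectation rests on the two values alone and on the size of the change. For compound 3 the step of a 1.3-fold higher number from compound 2 to compound 3 (0.12 log units; within the scatter) is expected to be small, upward if anything, and may well stay within the scatter. Compound 3 is therefore estimated at 8000 nM, within a range from 2500 nM to 25000 nM.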

Compound 3, solubility: 13500 nM
Compound 3: middle estimate off by 1.7-fold (0.23 log units), on the low side; the range from low to high includes it.
By their numbers in this assay, from the lowest: compound 2; then compounds 1 and 3 (each within the scatter of the next).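

Among these compounds, on an aromatic carbon of the shared core, the exchange of 5-cyanopentyl for 1H-pyrazol-5-yl gives the first single change that can be read in this assay, with a 2.3-fold higher number from compound 2 to compound 3 (0.35 log units; beyond the scatter) as a modest upward step. An open chain with a triple bond leaves and a five-membered aromatic ring with a hydrogen-bond donor enters, so several things differ at once, and one pair cannot separate them. Nothing measured here accounts for the step.

From the compounds shown here alone, whether the rise belongs to the 1H-pyrazol-5-yl group itself or simply to the loss of the chain stays open, and a phenyl ring, a shorter nitrile chain or an amine at this position would help to tell these apart. Whether the same exchange gives a similar step without the tert-butyl group is also unknown.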